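A few compounds are considered here, and "the series" means these few. Any claim that something is new, unique, unknown or untested is made for them only; others in the source may bear on it.

Of the compounds shown here, three that share one core have been measured in an ADME assay (liver) for metabolic stability, with Liver microsome (Homo sapiens) as the target, read by LC-MS, using microsomes, tested at 1 uM (a higher number here means that the compound lasts longer, a lower number that the compound disappears faster), and they differ only in the group on one aromatic carbon. Compound 1 `CNc1nc(NCCCN(C)C)c2sc(-c3ccc(-n4cccn4)cc3)cc2n1` gives 1.66 h, compound 2 `CNc1nc(NCCCN(C)C)c2sc(-c3ccc(C(C)=O)cc3)cc2n1` gives 0.35 h, and compound 3 `CNc1nc(NCCCN(C)C)c2sc(-c3ccc(N4CCNCC4)cc3)cc2n1` gives 0.8 h. Compound 3 therefore holds the middle place of the three. The two steps that reach it are a 2.1-fold lower number from compound 1 to compound 3 (0.32 log units; beyond the scatter) and a 2.3-fold higher number from compound 2 to compound 3 (0.36 log units; beyond the scatter). Both lie beyond the scatter, but both are modest.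

Going by the values given here, compound 4 `CNc1nc(NCCCN(C)C)c2sc(-c3ccccc3)cc2n1` has no measurement yet. The change is hydrogen in place of piperazin-1-yl on an aromatic carbon, so the position is left without a substituent. Among the compounds with values here, none of the measured compounds has hydrogen at this position, so the data give no direction for this swap. Within the data shown here, they show only how far a swap at this position has moved the number so far. Even the widest such step, a 4.7-fold lower number from compound 1 to compound 2 (0.68 log units; beyond the scatter), is modest. With no direction to go on, no shift beyond the scatter is expected in this assay, and the expected step is no change at the digits printed from compound 3 to compound 4 (within the scatter). For compound 4 the estimated half-life is 0.8 h, with an expected range from 0.35 h to 1.8 h.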

Compound 4, half-life: 5.75 h
Compound 4: middle estimate off by 7.2-fold (0.86 log units), on the low side, and the stated range ends below it.
By their numbers in this assay, from the lowest: compound 2; then compound 3; then compound 1; then compound 4.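

Taking away piperazin-1-yl gives a 7.2-fold higher number from compound 3 to compound 4 (0.86 log units; beyond the scatter) in this assay and taking away acetyl gives a 16-fold higher number from compound 2 to compound 4 (1.22 log units; beyond the scatter) while taking away 1H-pyrazol-1-yl gives a 3.5-fold higher number from compound 1 to compound 4 (0.54 log units; beyond the scatter) as well. The earlier compounds shown here compared one group with another, whereas these steps set each group against the bare position, and in all three comparisons the compound with hydrogen has the longer half-life, with no compound here going against this. Going by these compounds alone, the size of the step depends on the group that leaves, and only the step from the acetyl compound counts as large, but nothing available explains these differences or identifies which part of any compound is lost in the assay.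

From the compounds shown here alone, whether a single fluorine atom or a methyl group at this position would keep the half-life close to that of compound 4 remains open. Going by these compounds, it is also open whether a simple amine, a carboxylic acid or a longer chain there would follow the three groups seen so far, and whether the same order would hold on a different core.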